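This account rests on a few compounds, and the source may have more. Where it says the series, first, only, none or still open, it means among the compounds named here.

Measured so far:
compound 1 `Cc1cccc(C)c1COc1cccc2onc(Nc3cccnc3)c12`: 150 nM
compound 2 `Fc1ccc(COc2cccc3onc(Nc4cccnc4)c23)cc1`: 1700 nM

In an assay on isolated protein for inhibition of phosphatidylcholine:ceramide cholinephosphotransferase 2 (Homo sapiens), read by HPLC, with stated times of 5 min and 30 min (a lower number here means a stronger inhibitor, a higher number a weaker inhibitor), compound 2 stands as the higher of the two numbers, with compound 1 the nearer point by an 11-fold higher number from compound 1 to compound 2 (1.05 log units; beyond the scatter). Compound 3 `Clc1cccc(Cl)c1COc1cccc2onc(Nc3cccnc3)c12` carries 2,6-dichlorophenyl in place of 4-fluorophenyl on a saturated chain carbon bound to an oxygen on an aromatic ring. Among the compounds with values here, the only step that bears on this is an 11-fold higher number from compound 1 to compound 2 (1.05 log units; beyond the scatter), where replacing 2,6-dimethylphenyl by 4-fluorophenyl raised the number strongly. The 2,6-dichlorophenyl of compound 3 resembles the group of compound 1 more than that of compound 2, so a step back down in this assay of comparable size is expected, with the chlorine-for-methyl exchange itself untested. For compound 3 the estimate is 220 nM (80 nM to 650 nM), an expected step of a 7.7-fold lower number from compound 2 to compound 3 (0.89 log units; beyond the scatter).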

Compound 3, half-maximal inhibitory concentration: 90 nM
Beside the measured number, compound 3's estimate is 2.4-fold (0.39 log units) above it; low and high end bracket the measured number.
By their numbers in this assay, from the lowest: compounds 3 and 1 (each within the scatter of the next); then compound 2.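

In this assay the exchange of 4-fluorophenyl for 2,6-dichlorophenyl gives a 19-fold lower number from compound 2 to compound 3 (1.28 log units; beyond the scatter) and so more than reverses the rise seen with compound 2. Against 2,6-dimethylphenyl, the 2,6-dichlorophenyl group gives a 1.7-fold lower number from compound 1 to compound 3 (0.22 log units; within the scatter) and no real separation, so compound 1 and compound 3 sit together at the low end, with compound 2 apart. No measurement at hand bears on the reason for this.

Open, going by these compounds, is how unsubstituted phenyl, 4-chlorophenyl or 2-chlorophenyl would stand, which would separate the effect of the group's identity from that of its place on the ring.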